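Swapping Methoxy for Trifluoromethyl on Compound 3

The compounds below may be only part of what the source reports. "The series", "measured", "known", "first", "only" and "open" are said of these compounds alone.

Of the compounds shown here, three have been measured in an ADME assay on THP-1 cells (Homo sapiens) for cytotoxicity, read by flow cytometry and propidium iodide staining, with a stated time of 72 h; on this read-out lower numbers stand for stronger inhibition and higher numbers for weaker inhibition. Compound 1 `COc1ccc(-c2cc(=O)c3cc(NC(C)=O)ccc3o2)cc1` gives 74000 nM, compound 2 `CC(=O)Nc1ccc2oc(-c3cccc(C(F)(F)F)c3)cc(=O)c2c1` gives 50000 nM, and compound 3 `COc1ccc(-c2cc(=O)c3cc(N)ccc3o2)cc1` gives 124000 nM, which stands as the highest of the three numbers, though its gap to compound 1 is within the scatter while its gap to compound 2 is beyond it. Going by the values given here, the only single-point step, a 1.7-fold higher number from compound 1 to compound 3 (0.22 log units; within the scatter), concerns a substituent on nitrogen rather than the ring changed here. Compound 4 `Nc1ccc2oc(-c3ccc(C(F)(F)F)cc3)cc(=O)c2c1` differs from compound 3 by trifluoromethyl in place of methoxy on an aromatic carbon. Among the compounds with values here, no measured step bears directly on this change; compounds 1 and 2, which carry these two groups among other differences, show values lying close together. The step is therefore expected to be small, a 1.5-fold lower number from compound 3 to compound 4 (0.16 log units; within the scatter). Compound 4 is estimated at 85000 nM, within 40000 nM to 180000 nM.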

Compound 4, half-maximal inhibitory concentration: 1900 nM
Compound 4: middle estimate off by 45-fold (1.65 log units), on the high side; measured number outside the range, below it.
By their numbers in this assay, from the lowest: compound 4; then compounds 2, 1 and 3 (each within the scatter of the next, the first and the last beyond it).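

Trifluoromethyl in place of methoxy gives a 65-fold lower number from compound 3 to compound 4 (1.81 log units; beyond the scatter) in this assay, so the group on this aromatic carbon, para to a large group, can shift the number strongly. Going by these compounds alone, the only earlier single-place step, on the nitrogen, stayed within the scatter, which makes this the first such change here to move the number clearly. Nothing measured here explains the size of this step. Going by these compounds, whether a nitrile or a chlorine atom on this carbon would give a similar step stays open. So does whether the step would hold with acetyl on the nitrogen.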